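The source may report more compounds than this note shows. Statements on the series, on what has been measured and on what is new or still open speak of the compounds shown alone.

For the measured compounds named here, compound 3, with the structure `Nc1nc2c(nc(N)n2COCCO)c(=O)[nH]1`, is the only member of this small set for which a functional assay (Oryctolagus cuniculus) for inhibition (on this read-out lower numbers stand for stronger inhibition and higher numbers for weaker inhibition), yields an actual number: in that assay compound 3 gives 290 ug/mL. The two halogen analogues reach only limits. Compound 1, `Nc1nc2c(nc(Cl)n2COCCO)c(=O)[nH]1`, gives the limit > 400 ug/mL in this assay. Compound 2, `Nc1nc2c(nc(I)n2COCCO)c(=O)[nH]1`, gives the limit >= 350 ug/mL in this assay. The step that the two limits leave unreadable from compound 1 to compound 2 cannot be sized, because the limit of > 400 ug/mL in this assay, at which 1 of the 3 values shown sits, and the limit of >= 350 ug/mL in this assay, at which 1 of the 3 values shown sits, each cap the value. The two steps toward compound 3 read an at least 1.3-fold lower number from compound 1 to compound 3 (0.13 log units; that floor lies within the scatter) and an at least 1.2-fold lower number from compound 2 to compound 3 (0.08 log units; that floor lies within the scatter); both floors sit within the scatter, so compound 3 cannot be called more active than the others.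

Compound 4, `CNc1nc2c(=O)[nH]c(N)nc2n1COCCO`, is not yet measured. It differs from compound 3 by methyl in place of hydrogen on a nitrogen on an aromatic ring. Going by the values given here, none of the measured steps touches a change of this kind; all three concern what sits on the aromatic carbon, not on the nitrogen. The record therefore offers no basis for a shift beyond the scatter in either direction, and the expectation is that compound 4 will land close to compound 3. For compound 4 the estimate in this assay is 300 ug/mL, with a range from 100 ug/mL to 700 ug/mL. The step this estimate implies, a 1.0-fold higher number from compound 3 to compound 4 (0.01 log units; within the scatter), is expected to stay within the scatter.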

Compound 4, concentration for 50% inhibition: > 400 ug/mL
Compound 4 was reported as a limit; the forecaster's own chance of this, stated with the estimate: 50%; at least 1.3-fold (0.12 log units) between middle value and limit.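

In this assay, for the compounds shown here, methyl in place of hydrogen on a nitrogen on an aromatic ring gives an at least 1.3-fold higher number from compound 3 to compound 4 (0.13 log units; that floor lies within the scatter), the first step in this set that alters the amino group itself rather than exchanging the whole group on the aromatic carbon. Going by these compounds alone, that floor lies within the scatter, so the record does not establish a real difference between amino and methylamino; it shows only that this small change takes compound 4 from an actual number to a limit, leaving compound 3 as the only compound with a measured number. The steps from the two halogen compounds to compound 4 cannot be read, and compound 4 shares its limit with compound 1: the limit of > 400 ug/mL in this assay, at which 2 of the 4 values shown sit.

On these data alone, how far the true value of compound 4 lies past its limit remains unknown, so the real size of the step from the amino compound could be within the scatter or well beyond it. The compounds shown also leave open how a larger group on the same nitrogen, such as ethyl, or a dimethylamino group on the aromatic carbon, would read in this assay.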